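Thioether prodrug series: cytotoxicity of the truncated amide

This account rests on a few compounds, and the source may have more. Where it says the series, first, only, none or still open, it means among the compounds named here.

Measured so far:
compound 1, `NC(=O)CCNC(=O)c1cccc(S)c1`: > 100 uM
compound 2, `CCCC(=O)OCSc1ccccc1C(=O)NCCCC(N)=O`: 56.6 uM
compound 3, `CCCC(=O)OCSc1ccccc1C(=O)Nc1ccccc1C(N)=O`: 50.1 uM

In an ADME assay on CEM-SS cells (Homo sapiens) for cytotoxicity, read by XTT assay, with a stated time of 6 days (a higher number here means that more compound is tolerated, a lower number that less compound is tolerated), compound 2 gives 56.6 uM, the higher of the two numbers recorded. Compound 3 gives 50.1 uM, which lies within the scatter of the value for compound 2, so no order between the two is drawn. Compound 1 sits at the limit of > 100 uM in this assay, at which 1 of the 3 values shown sits, a limit of the assay and not a number.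

Compound 4, `CCCC(=O)OCSc1ccccc1C(N)=O`, awaits measurement. It differs from compound 2 by hydrogen in place of 3-carbamoylpropyl on an amide-type nitrogen, the change sitting on an amide-type nitrogen whose other neighbour is a carbonyl carbon. Within the data shown here, no measured pair in the set shows a step of this kind, so the expectation rests on compound 2 alone. For compound 4 an estimate of 50 uM is made, ranging from 20 uM to 130 uM. The expected step of a 1.1-fold lower number from compound 2 to compound 4 (0.05 log units; within the scatter) is none beyond the scatter.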

Compound 4, half-maximal toxic concentration: 12.4 uM
Compound 4: the middle estimate sits 4.0-fold (0.61 log units) above what was measured, outside the stated range (below it).
By their numbers in this assay, from the lowest: compound 4; then compounds 3 and 2 (each within the scatter of the next). At a limit, above all of these: compound 1.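

The position is not neutral: on an amide-type nitrogen whose other neighbour is a carbonyl carbon, hydrogen in place of 3-carbamoylpropyl gives, in this assay, a 4.6-fold lower number from compound 2 to compound 4 (0.66 log units; beyond the scatter), the first single-place step readable in the series. Less compound is tolerated once the chain leaves. Nothing measured here accounts for the size of this step.

Still open, on these data alone, is whether the step follows the chain itself or its terminal carbamoyl. A plain butyl chain, or a carboxylic acid at the chain end, on the same nitrogen would separate the two.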